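Shortening the side chain: a return toward weaker inhibition?

This account rests on a few compounds, and the source may have more. Where it says the series, first, only, none or still open, it means among the compounds named here.

Measured in a functional assay on HeLa cells (Homo sapiens) for cytotoxicity, read by WST assay, with a stated time of 48 h; on this read-out higher numbers stand for weaker inhibition and lower numbers for stronger inhibition
compound 1 `COc1cc(C(c2ccc(O)c(OC)c2)[C@@H](C)[C@H](C)CF)ccc1O` gives 37000 nM
compound 2 `CCCCC[C@H](C(C)C)C(c1ccc(O)c(OC)c1)c1ccc(O)c(OC)c1` gives 9200 nM

Of these two compounds, compound 2 holds the lower number, 9200 nM, and so shows the stronger inhibition. Compound 3 `COc1cc(C(c2ccc(O)c(OC)c2)[C@H](C)[C@@H](C)CF)ccc1O` has not yet been measured. It differs from compound 2 in one place, (2-(fluoromethyl)-1-methylpropyl in place of 1-isopropylhexyl on a saturated chain carbon bound to two aromatic carbons), with 2-(fluoromethyl)-1-methylpropyl in place of 1-isopropylhexyl on a saturated chain carbon bound to two aromatic carbons. Going by the values given here, one measured step bears on this change, a 4.0-fold lower number from compound 1 to compound 2 (0.60 log units; beyond the scatter), and it is modest but beyond the scatter. Among the compounds with values here, compound 1 carries a group of the same name, but its stereocentres are drawn the opposite way, and no measured step covers that difference. The same exchange run in reverse should therefore raise the number in this assay by a similar amount. The expected change is a 3.5-fold higher number from compound 2 to compound 3 (0.54 log units; beyond the scatter). For compound 3 the estimated value is 32000 nM, with an expected range of 13000 nM to 80000 nM.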

Compound 3, half-maximal inhibitory concentration: 34000 nM
Compound 3: the middle estimate sits 1.1-fold (0.03 log units) below what was measured, and the stated range covers the measured number.
By their numbers in this assay, from the lowest: compound 2; then compounds 3 and 1 (each within the scatter of the next).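

In this assay, placing 2-(fluoromethyl)-1-methylpropyl in place of 1-isopropylhexyl on a saturated chain carbon bound to two aromatic carbons gives a 3.7-fold higher number from compound 2 to compound 3 (0.57 log units; beyond the scatter). The earlier measurements covered this exchange with only one drawn configuration of the entering group, whereas inverting both of its stereocentres now gives a 1.1-fold lower number from compound 1 to compound 3 (0.04 log units; within the scatter), so the two mirror images cannot be told apart in this assay. This pair isolates configuration from every other structural change: the fact that compounds 1 and 3 differ only in the configuration as drawn

The compounds shown do not separate the contribution of the fluorine from that of chain length, which both change in the exchange, and a longer chain carrying the same fluoromethyl group would bear on that question. They also leave open the two remaining configurations of 2-(fluoromethyl)-1-methylpropyl, in which only one of its stereocentres is inverted.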